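Chloro in place of hydrogen: notes on compound 3

This account rests on a few compounds, and the source may have more. Where it says the series, first, only, none or still open, it means among the compounds named here.

Measured so far in a functional assay on NCI-H460 cells (Homo sapiens) for inhibition, read by MTT assay, with a stated time of 24 h, tested at 0.1 ug/mL (a lower number here means less inhibition of growth, a higher number more inhibition of growth at the concentration tested), as follows
compound 1 `Cc1cccc(NC(=O)CCCCC(S)CCS)c1` gives 9.34%
compound 2 `O=C(CCCCC(CCSC(=O)c1ccccc1)SC(=O)c1ccccc1)Nc1ccccc1` gives 0.6%

In this assay compound 2 gives 0.6% and lies within the scatter of compound 1 at 9.34% so neither ranks above the other. Compound 3 `O=C(CCCCC(CCSC(=O)c1ccccc1)SC(=O)c1ccccc1)Nc1ccc(Cl)cc1` differs from compound 2 by one change chloro in place of hydrogen on an aromatic carbon with chloro in place of hydrogen on an aromatic carbon, para to a large group. Among the measured compounds shown here, no measured step covers this change, and no shift beyond the scatter is expected. The expected step is a number 3.4 percentage points higher from compound 2 to compound 3 (within the scatter) and it stays within the scatter. Compound 3 is estimated at 4% with an expected range from 0% to 14% in this read-out.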

Compound 3, percent growth inhibition at one concentration: 9.36%
Compound 3: middle estimate off by 5.4 percentage points, on the low side; the range from low to high includes it.
By their numbers in this assay, from the lowest: compounds 2, 1 and 3 (each within the scatter of the next).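

In this assay, among the compounds shown here, chloro in place of hydrogen on an aromatic carbon, para to a large group, gives a first measured step at this position: a number 8.8 percentage points higher from compound 2 to compound 3 (within the scatter). Phenyl to 4-chlorophenyl therefore stays within the scatter, and this single step cannot separate the change from no effect at this concentration. No supporting measurement bears on this result.

Open, as far as these compounds go, is how an amine, a carboxylic acid or a methoxy group on this same aromatic carbon would read. Also open, from the compounds shown here alone, is whether the chloro step would hold at another test concentration.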